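This account rests on a few compounds, and the source may have more. Where it says the series, first, only, none or still open, it means among the compounds named here.

Of the compounds shown here, three have so far been tested in an assay on isolated protein for displacement of a labelled ligand from metabotropic glutamate receptor 5 (Homo sapiens), with a stated time of 60 min, tested at 1 uM; on this read-out lower numbers stand for less inhibition and higher numbers for more inhibition at the one concentration tested (going by the name of the read-out). Compound 1 `COc1ccc(S(=O)(=O)c2cnc3ccc(F)cc3c2N2CCC(C)CC2)cc1` gives 85% in this assay, the highest of the three numbers. Compound 2 `CC1CCN(c2c(S(=O)(=O)c3cccc(F)c3)cnc3ccc(Cl)cc23)CC1` gives 58%, a number that lies beyond the usual scatter below compound 1. Compound 3 `CCN1CCN(c2c(S(=O)(=O)c3ccccc3)cnc3ccccc23)CC1` gives 1.7%, far below both of the others. No two of these three compounds differ in only one place, so none of the gaps between them can be tied to a single change.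

Going by the values given here, compound 4 `CC1CCN(c2c(S(=O)(=O)c3ccc(F)cc3)cnc3ccc(F)cc23)CC1` is the one compound not yet measured. It differs from compound 1 in a single place: fluoro in place of methoxy on an aromatic carbon. The gap between compound 1 and compound 2 is not a clean guide here, because compound 2 at 58% also carries a different group on the shared core. Among the compounds with values here, no measured step for this exact change exists, so the expectation for compound 4 rests mainly on compound 1 holding 85%. The step from compound 1 to compound 4 is expected to be a number 13 percentage points lower from compound 1 to compound 4 (beyond the scatter), a drop that may well fall within the scatter. Compound 4 is therefore estimated to give 72% in this assay, within a range from 48% to 90%.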

Compound 4, a percentage reported as inhibition, at one concentration (the size of the read-out at that concentration, not a potency): 87%
Compound 4: middle estimate off by 15 percentage points, on the low side, and the stated range covers the measured number.
By their numbers in this assay, from the lowest: compound 3; then compound 2; then compounds 1 and 4 (each within the scatter of the next).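

Going by these compounds alone, this is the first pair that differs in one place only, so the step can be tied to a single change: in this assay, replacing 4-methoxyphenyl with 4-fluorophenyl gives a number 2 percentage points higher from compound 1 to compound 4 (within the scatter). On this aromatic carbon, para to a large group, the methoxy with its 2 heavy atoms and 1 hydrogen-bond acceptor can therefore give way to a fluoro with 1 heavy atom and 0 hydrogen-bond acceptors, and the two numbers cannot be told apart. The hydrogen-bond acceptor and the extra heavy atom of the methoxy are thus not needed to keep the read-out at this level on this core, but no measurement here explains why the two groups read alike.

The compounds shown leave open whether an amine, a carboxylic acid or a longer chain such as butoxy at the same place would also keep the number at this level, as only methoxy and fluoro can be compared there. Also open, from the compounds shown here alone, is whether the same replacement would give a similar step on a different core, as this single pair rests on the core of compound 1 alone.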